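Toward compound 3: a smaller group on the shared core

The source may hold more compounds than are shown below. What is called first, only, known or untested is meant among the compounds shown, and "the series" means these compounds.

Among the measured compounds shown here, in an ADME assay on microsomes from liver (Homo sapiens) for metabolic stability (on this read-out lower numbers stand for slow clearance and higher numbers for fast clearance), compound 2 (`CCCC(Oc1ccc(-n2cc3c(n2)CCCC3)cc1)c1ccc(C(=O)NCCC(=O)O)cc1`) gives 48 mL/min/kg as the only actual number so far. Compound 1 (`CCCC(Oc1ccc(-n2cc(C(F)(F)F)c(C)n2)cc1)c1ccc(C(=O)NCCC(=O)O)cc1`) stands at < 10 mL/min/kg which is a limit of the assay and not a number.

The change from compound 2 to compound 3 (`CCCC(Oc1ccc(-n2cc(C)cn2)cc1)c1ccc(C(=O)NCCC(=O)O)cc1`) is a group of 6 heavy atoms (4 carbon, 2 nitrogen; one five-membered aromatic ring with 2 hetero atoms) in place of a group of 9 heavy atoms (7 carbon, 2 nitrogen; one five-membered aromatic ring with 2 hetero atoms, one six-membered non-aromatic ring of carbon only), on an aromatic carbon and it places 4-methyl-1H-pyrazol-1-yl on an aromatic carbon, para to a large group, with the six-membered non-aromatic ring of carbon only gone.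

For the measured compounds named here, the one measured step that bears on this is an at least 4.8-fold higher number from compound 1 to compound 2 (0.68 log units; beyond the scatter) and it lies beyond the scatter, with its size bounded on one side only. Compound 3 shares with compound 1 the absence of that six-membered ring, but it also lacks the trifluoromethyl group of compound 1, so only part of that step is expected to return. The estimated step is a 2.4-fold lower number from compound 2 to compound 3 (0.38 log units; beyond the scatter) and it points toward slower clearance. Compound 3 is expected in this assay at 20 mL/min/kg with an estimated range from 10 mL/min/kg to 42 mL/min/kg for the coming measurement.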

Compound 3, clearance: 16 mL/min/kg
Compound 3: middle estimate off by 1.3-fold (0.10 log units), on the high side, and the stated range covers the measured number.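

Removing the six-membered non-aromatic ring of carbon only, with 4-methyl-1H-pyrazol-1-yl entering on the aromatic carbon para to a large group, gives a 3.0-fold lower number from compound 2 to compound 3 (0.48 log units; beyond the scatter) in this assay. The trifluoromethyl group is absent from compound 3, so this position on the shared core can give a clearance well under that of compound 2 without that group, which the step from compound 1 to compound 2 alone could not show. Compound 1 sits at a limit of the assay and not at a number, so an at least 1.6-fold higher number from compound 1 to compound 3 (0.20 log units; that floor lies within the scatter) is only a floor, and what 3-methyl-4-(trifluoromethyl)-1H-pyrazol-1-yl adds over 4-methyl-1H-pyrazol-1-yl stays unresolved because of that limit: the limit of < 10 mL/min/kg in this assay, at which 1 of the 3 values shown sits.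

The compounds shown leave open whether the trifluoromethyl group or the 3-methyl group of compound 1 accounts for any part of that difference, since the two always appear together here. They also do not tell how a nitrile or a methoxy group in place of the methyl group of 4-methyl-1H-pyrazol-1-yl would read in this assay.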